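An amino group added to a compound at the limit

This account rests on a few compounds, and the source may have more. Where it says the series, first, only, none or still open, it means among the compounds named here.

In a functional assay on K562 cells (Homo sapiens) for cytotoxicity, read by MTT assay, with a stated time of 5 days (a higher number here means a weaker inhibitor, a lower number a stronger inhibitor), compound 1 `COc1ccc(-c2cn(-c3cc(OC)c(OC)c(OC)c3)nn2)cc1N` gives 1300 nM. Compound 2 `COc1ccc(-c2cn(Cc3cc(OC)c(OC)c(OC)c3)nn2)cc1` gives only a limit, > 10000 nM, and not a true number. As far as these compounds go, it therefore sits at the weak end of the two results so far, and its exact place is unknown.

Compound 3 `COc1ccc(-c2cn(Cc3cc(OC)c(OC)c(OC)c3)nn2)cc1N` differs from compound 2 in one place: amino in place of hydrogen on an aromatic carbon. An amino group takes the place of a hydrogen on an aromatic carbon, ortho to a methoxy group, turning 4-methoxyphenyl into 3-amino-4-methoxyphenyl.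

Going by the values given here, no measured pair shows this change alone, which leaves only indirect evidence for its size. Compound 1 also carries the 3-amino-4-methoxyphenyl group and gives 1300 nM, which suggests that a number within the measurable range is possible. A clear move towards stronger inhibition is therefore expected, estimated as an at least 3.3-fold lower number from compound 2 to compound 3 (0.52 log units; beyond the scatter), although the starting point is only a limit and compound 3 could also end at the limit. For compound 3 the estimated value is 3000 nM, with an expected range of 600 nM to 10000 nM.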

Compound 3, half-maximal inhibitory concentration: > 10000 nM
Compound 3 ended at the assay's limit; the forecaster's own chance of this, stated with the estimate: 25%; middle value at least 3.3-fold (0.52 log units) away from the limit.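

In this assay compound 3 gives > 10000 nM, which is a limit and not a true number. Compound 2 also stands at a limit, so no step can be read between these two compounds: the limit of > 10000 nM in this assay, at which 2 of the 3 values shown sit.

The compounds shown leave open whether the amino group changes the activity of compound 2 at all, and where the true values of compound 2 and compound 3 lie.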